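Amide to Urea: Expected Gain at the Carbonyl

The source may hold more compounds than are shown below. What is called first, only, known or untested is meant among the compounds shown, and "the series" means these compounds.

Compound 1 `COc1cc(-c2nn(-c3cccc(NC(=O)c4ccc(Cl)c(C(F)(F)F)c4)c3)cc2-c2ccncc2)ccc1Cl` in a functional assay on ACHN cells (Homo sapiens) for inhibition, read by sulforhodamine B assay, with a stated time of 48 h (on this read-out lower numbers stand for stronger inhibition of growth and higher numbers for weaker inhibition of growth), gives > 32500 nM, which is a limit of the assay and not a number. Compound 2 `COc1cc(-c2nn(-c3cccc(NC(=O)Nc4cccc(C(F)(F)F)c4)c3)cc2-c2ccncc2)ccc1Cl` gives 3720 nM. Compound 3 `O=C(Nc1cccc(-n2cc(-c3ccncc3)c(-c3ccc(Cl)c(O)c3)n2)c1)Nc1cccc(C(F)(F)F)c1` gives > 32500 nM, again only a limit. Both compound 1 and compound 3 sit at the limit of > 32500 nM in this assay, at which 2 of the 3 values shown sit, so their steps are known only as minimum sizes: an at least 8.7-fold lower number from compound 1 to compound 2 (0.94 log units; beyond the scatter) and an at least 8.7-fold higher number from compound 2 to compound 3 (0.94 log units; beyond the scatter). Compound 4 `COc1cc(-c2nn(-c3cccc(NC(=O)Nc4ccc(Cl)c(Cl)c4)c3)cc2-c2ccncc2)ccc1Cl` carries (3,4-dichlorophenyl)amino in place of 4-chloro-3-(trifluoromethyl)phenyl on a carbonyl carbon. This is the same amide-to-urea change that produced the step from compound 1 to compound 2, so a drop of similar size is expected; the step from compound 1 to compound 4 is estimated as an at least 8.1-fold lower number from compound 1 to compound 4 (0.90 log units; beyond the scatter). Compound 4 is therefore expected to show 4000 nM, within 1500 nM to 15000 nM.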

Compound 4, concentration for total growth inhibition: > 50000 nM
Compound 4 gave a limit, no number; the forecaster's own chance of this, stated with the estimate: 15%; middle value at least 12-fold (1.09 log units) away from the limit.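

Compound 4 sits at a limit of the assay, not at a number: the limit of > 50000 nM in this assay, at which 1 of the 4 values shown sits. With the urea kept, 3,4-dichlorophenyl in place of 3-(trifluoromethyl)phenyl on the amide-type nitrogen gives an at least 13-fold higher number from compound 2 to compound 4 (1.12 log units; beyond the scatter), so among these compounds the urea alone does not bring the lower number seen with compound 2; the aryl group on it matters as well. The step from compound 1 to compound 4 cannot be read, since both ends are limits.

Going by these compounds, it remains open whether a plain phenyl on that nitrogen, or a phenyl carrying a nitrile in place of trifluoromethyl, would keep a measurable value.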